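From Benzyl Ester to Aminopropyl Side Chain

This account rests on a few compounds, and the source may have more. Where it says the series, first, only, none or still open, it means among the compounds named here.

Compound 1 `C[C@@H](O)[C@H](NC(=O)CN(c1nc(Cl)nc2[nH]cnc12)C1CC1)C(=O)OCc1ccccc1`: 21.9%
Compound 2 `O=C(CN(c1nc(Cl)nc2[nH]cnc12)C1CC1)N[C@@H](CC(=O)OCc1ccccc1)C(=O)OCc1ccccc1`: 34.7%

Both were measured in a functional assay on the whole organism (Tail, strain ICR) with Mus musculus as the target, in the tail flick test, with a stated time of 30 min, at a dose of 25 umol/kg by the oral route; on this read-out higher numbers stand for a stronger effect at the one dose given and lower numbers for a weaker effect. Among these two numbers compound 2 stands highest; the only measured step, a number 12.8 percentage points higher from compound 1 to compound 2 (beyond the scatter), reworked the side chain on the same chain carbon. Compound 3 `NCCCC[C@H](NC(=O)CN(c1nc(Cl)nc2[nH]cnc12)C1CC1)C(=O)OCc1ccccc1` differs from compound 2 by 3-aminopropyl in place of benzyloxycarbonyl on a saturated chain carbon, two bonds along the chain from an amide-type nitrogen and a carbonyl carbon. Going by the values given here, no measured step covers this exchange; the one step shows only that the side chain at this carbon shifts the read-out by a modest amount. Compound 3 is therefore expected to fall back toward compound 1, with an estimated step of a number 12.7 percentage points lower from compound 2 to compound 3 (beyond the scatter) in this assay, giving 22% within 8% to 38%.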

Compound 3, a percentage reported as activity, at one dose (the size of the read-out at that dose, not a potency): 26.1%
The estimate for compound 3 lay 4.1 percentage points below the measured number; low and high end bracket the measured number.
By their numbers in this assay, from the lowest: compounds 1, 3 and 2 (each within the scatter of the next, the first and the last beyond it).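

In this assay, 3-aminopropyl in place of benzyloxycarbonyl gives a number 8.6 percentage points lower from compound 2 to compound 3 (within the scatter), and 4-aminobutyl in place of 1-hydroxyethyl gives a number 4.2 percentage points higher from compound 1 to compound 3 (within the scatter). This position therefore accepts a side chain ending in an amine, with no ring, and the read-out stays within the scatter of both earlier compounds, although those two differ beyond it. No measured evidence explains these numbers. As far as these compounds go, it remains open how a free carboxylic acid at this carbon, or a longer chain ending in an amine, would read.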